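Swapping a Methylamino for an Azetidine Ring

The compounds below may be only part of what the source reports. "The series", "measured", "known", "first", "only" and "open" are said of these compounds alone.

Of the compounds shown here, three sharing one core have been tested in an assay on isolated protein for displacement of a labelled ligand from melanin-concentrating hormone receptor 1 (Homo sapiens); on this read-out higher numbers stand for weaker inhibition and lower numbers for stronger inhibition. Compound 1, `CCCc1cc(NC)c2cc(NC(=O)/C=C/c3ccc(C(F)(F)F)cc3)ccc2n1`, gives 1.5 nM in this assay. Among the three numbers that is the second highest. The closest neighbour is compound 3, `CCC(C)c1cc(N)c2cc(NC(=O)/C=C/c3ccc(C(F)(F)F)cc3)ccc2n1`, which gives 0.3 nM in this assay, a lower number that lies beyond the usual scatter. The furthest is compound 2, `CCCc1cc(N)c2cc(NC(=O)/C=C/c3cccc(Cl)c3)ccc2n1`, which gives 1100 nM in this assay, a far higher number and well beyond the scatter.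

The next compound, compound 4, `CCCc1cc(N2CCC2)c2cc(NC(=O)/C=C/c3ccc(C(F)(F)F)cc3)ccc2n1`, has not yet been measured. Compared with compound 1 the change is azetidin-1-yl in place of methylamino on an aromatic carbon. A hydrogen-bond donor is lost and a small ring is gained at the same position, while the rest of the molecule stays as in compound 1.

Going by the values given here, no measured pair among the three compounds covers this exact change, so the expectation rests on compound 1 alone. The expected step is a 2.7-fold higher number from compound 1 to compound 4 (0.43 log units; beyond the scatter), a mild shift toward a higher number that may or may not exceed the scatter. For compound 4 the estimated value in this assay is 4 nM, with a range from 1 nM to 20 nM.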

Compound 4, half-maximal inhibitory concentration: 2.8 nM
Estimate against measurement, compound 4: 1.4-fold (0.15 log units) above, and the stated range covers the measured number.
By their numbers in this assay, from the lowest: compound 3; then compounds 1 and 4 (each within the scatter of the next); then compound 2.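

In this assay putting azetidin-1-yl in place of methylamino gives a 1.9-fold higher number from compound 1 to compound 4 (0.27 log units; within the scatter), so this read-out does not separate the two compounds. Going by these compounds alone, compounds 1, 2 and 3 all keep a hydrogen on the nitrogen attached to this aromatic carbon, opposite the ring nitrogen, while azetidin-1-yl brings 0 hydrogen-bond donors, a four-membered ring and more heavy atoms; this pair is therefore the first look at the position without that hydrogen, and here the combined change stays within the scatter. No measurement shown here offers an explanation for this result.

Going by these compounds, the loss of the hydrogen and the gain of the ring happen together, so their separate contributions remain unknown; a dimethylamino group, which has no such hydrogen and no ring, or a larger pyrrolidine ring on the same carbon would help to pull them apart. On these data alone, it also remains open whether the swap would give a similarly small step with a chain other than the propyl group on the shared core.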